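A few compounds are considered here, and "the series" means these few. Any claim that something is new, unique, unknown or untested is made for them only; others in the source may bear on it.

Working notes on the series. In a functional assay on the whole organism (strain Wistar) for inhibition, with Rattus norvegicus as the target, read by paw edema, with a stated time of 1 h, at a dose of 10 mg/kg by the intraperitoneal route (on this read-out lower numbers stand for less inhibition and higher numbers for more inhibition at the one dose given (going by the name of the read-out)), compound 1 `COc1cc(/C=C/C(=O)/C=C(O)/C=C/c2ccc(OC(=O)CNC(=O)OCc3ccccc3)c(OC)c2)ccc1OC(=O)CNC(=O)OCc1ccccc1` gives 64%, compound 2 `COc1cc(/C=C/C(=O)/C=C(O)/C=C/c2ccc(OC(=O)C(C)NC(=O)OCc3ccccc3)c(OC)c2)ccc1OC(=O)C(C)NC(=O)OCc1ccccc1` gives 72%, and compound 3 `COc1cc(/C=C/C(=O)/C=C(O)/C=C/c2ccc(OC(=O)[C@@H](C)NC(=O)OCc3ccccc3)c(OC)c2)ccc1OC(=O)[C@@H](C)NC(=O)OCc1ccccc1` gives 82%. Compound 3 carries the highest number shown, but its gap to compound 2 is within the scatter; only the gap to compound 1 is beyond it. The step that bears on the next compound is a number 10 percentage points higher from compound 2 to compound 3 (within the scatter), whose only distinguishing feature is the fact that one of compounds 2 and 3 is drawn with a defined configuration and the other without, at the place where they differ. Compound 4 `COc1cc(/C=C/C(=O)/C=C(O)/C=C/c2ccc(OC(=O)[C@H](C)NC(=O)OCc3ccccc3)c(OC)c2)ccc1OC(=O)[C@H](C)NC(=O)OCc1ccccc1` differs from compound 3 as follows: the two compounds have the same atoms and bonds and differ only in configuration as drawn: 2 of 5 stereo elements differ; a stereocentre at a saturated chain carbon is drawn R in compound 3 and S in compound 4; a stereocentre at a saturated chain carbon is drawn R in compound 3 and S in compound 4. On this evidence no shift beyond the scatter in this assay is expected from the mirror configuration, at most a modest drop. Compound 4 is therefore expected to give about 68%, between 52% and 82%, a step of a number 14 percentage points lower from compound 3 to compound 4 (beyond the scatter).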

Compound 4, a percentage reported as inhibition, in the whole organism at one dose (the size of the read-out at that dose, not a potency): 56%
Beside the measured number, compound 4's estimate is 12 percentage points above it, and the stated range covers the measured number.
By their numbers in this assay, from the lowest: compounds 4, 1, 2 and 3 (each within the scatter of the next, the first and the last beyond it).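

In this assay, configuration at the two saturated chain carbons now shows a difference beyond the scatter, which the earlier comparison of undefined and R drawings did not: a number 26 percentage points lower from compound 3 to compound 4 (beyond the scatter). The S drawing also separates from the undefined one, with a number 16 percentage points lower from compound 2 to compound 4 (beyond the scatter). The larger step goes with configuration alone, with no atom or bond changed: the fact that compounds 3 and 4 differ only in the configuration as drawn

The compounds shown leave open whether one chain carbon alone carries this gap, as both change together. Also open, going by these compounds, is whether the gap between R and S survives with a longer chain at these carbons or a free amine in place of the carbamate.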